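A Chloro-to-Hydrogen Change in a Triazine Series

This account rests on a few compounds, and the source may have more. Where it says the series, first, only, none or still open, it means among the compounds named here.

Measured compounds:
compound 1, `N#Cc1ccc(Nc2nc(Oc3ccnc4ccccc34)nc(N3CCCCC3)n2)cc1C(F)(F)F`: > 100000 nM
compound 2, `N#Cc1ccc(Nc2nc(Oc3ccnc4ccccc34)nc(N3CCN(c4ccccc4Cl)CC3)n2)cc1C(F)(F)F`: > 100000 nM
compound 3, `COc1ccc(CN2CCN(c3nc(Nc4ccc(C#N)c(C(F)(F)F)c4)nc(Oc4ccnc5ccccc45)n3)CC2)c(OC)c1OC`: > 100000 nM

The three measured compounds share one core and differ only in the amine attached to it. In a functional assay on DU-145 cells (Homo sapiens) for cytotoxicity, read by sulforhodamine B assay, with a stated time of 48 h (on this read-out higher numbers stand for weaker inhibition of growth and lower numbers for stronger inhibition of growth), compound 1 gives > 100000 nM, which is a limit of the assay and not a number. In this assay compound 2 gives > 100000 nM, again a limit rather than a number. In this assay compound 3 gives > 100000 nM, also a limit. Among the compounds with values here, compound 2 therefore stands where every measured compound stands: at the limit of > 100000 nM in this assay, at which 3 of the 3 values shown sit, so no step between measured compounds can be drawn, and nothing in the data sets compound 2 apart from compound 1 or compound 3.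

Compound 4, `N#Cc1ccc(Nc2nc(Oc3ccnc4ccccc34)nc(N3CCN(c4ccccc4)CC3)n2)cc1C(F)(F)F`, has not been measured in this assay. It differs from compound 2 by hydrogen in place of chloro on an aromatic carbon.

Within the data shown here, with no measured step to lean on, the expectation for compound 4 rests on compound 2 alone. The step of a number no higher from compound 2 to compound 4 (the limit leaves the size open) is expected to be none beyond the usual scatter. Compound 4 is expected to remain at the limit, with an estimate of 100000 nM and a range from 30000 nM to 300000 nM.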

Compound 4, concentration for total growth inhibition: > 100000 nM
Compound 4 was reported as a limit; the forecaster's own chance of this, stated with the estimate: 80%; the middle value sits exactly at the limit.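

In this assay compound 4 gives > 100000 nM, a limit of the assay and not a number. With limits on both sides, no step can be read from compound 1 or compound 2 to compound 4. The compounds shown leave open whether any amine on the shared core would give a numerical value in this assay.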